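Substituted benzyl ethers on the shared core: antiproliferative series

The compounds below may be only part of what the source reports. "The series", "measured", "known", "first", "only" and "open" are said of these compounds alone.

Measured so far:
compound 1 `COc1ccc2c(=O)c(-c3cc(OC)c(OC)cc3OC)coc2c1` — 2040 nM
compound 2 `COc1cc(OC)c(-c2coc3cc(OCc4ccccc4F)ccc3c2=O)cc1OC` — 1280 nM
compound 3 `COc1cc(OC)c(-c2coc3cc(OCc4cccc(Cl)c4)ccc3c2=O)cc1OC` — 750 nM

In a functional assay on HepG2 cells (Homo sapiens) for antiproliferative activity, read by MTT assay, with a stated time of 24 h (a lower number here means a stronger inhibitor, a higher number a weaker inhibitor), compound 1 gives 2040 nM, compound 2 gives 1280 nM and compound 3 gives 750 nM. Compound 3 has the lowest number of the three: the step of a 2.7-fold lower number from compound 1 to compound 3 (0.43 log units; beyond the scatter) is modest but beyond the scatter, whereas a 1.7-fold lower number from compound 2 to compound 3 (0.23 log units; within the scatter) stays within it, as does a 1.6-fold lower number from compound 1 to compound 2 (0.20 log units; within the scatter). So the substituted benzyl group brings a real gain over the bare phenol, but the two substituted benzyl groups cannot be separated.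

Compound 4 `COc1cc(OC)c(-c2coc3cc(OCc4cccc(C(F)(F)F)c4)ccc3c2=O)cc1OC` differs from compound 3 in one place: trifluoromethyl in place of chloro on an aromatic carbon. For the measured compounds named here, no measured step swaps one substituent for another on this ring in a way that directly covers this change; the only step that changes the substituent pattern, a 1.7-fold lower number from compound 2 to compound 3 (0.23 log units; within the scatter), lies within the scatter. On that basis the step of a 1.2-fold lower number from compound 3 to compound 4 (0.06 log units; within the scatter) is expected to be small, in either direction, and not beyond the scatter. Compound 4 is therefore expected to give about 650 nM in this assay, with a range from 320 nM to 1300 nM.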

Compound 4, half-maximal inhibitory concentration: 610 nM
Compound 4: the middle estimate sits 1.1-fold (0.03 log units) above what was measured; low and high end bracket the measured number.
By their numbers in this assay, from the lowest: compounds 4, 3, 2 and 1 (each within the scatter of the next, the first and the last beyond it).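

At this aromatic carbon, meta to a large group, chloro and trifluoromethyl cannot be separated in this assay: a 1.2-fold lower number from compound 3 to compound 4 (0.09 log units; within the scatter). Even so, 3-(trifluoromethyl)phenyl clears the scatter against 2-fluorophenyl, a 2.1-fold lower number from compound 2 to compound 4 (0.32 log units; beyond the scatter), where 3-chlorophenyl did not, and a 3.3-fold lower number from compound 1 to compound 4 (0.52 log units; beyond the scatter) also lies beyond the scatter, though this does not separate the two meta-substituted groups from each other. No supporting data are available to explain these readings.

The compounds shown leave open how a carboxylic acid, an amine or a nitrile would read at this aromatic carbon. Also open, going by these compounds, is whether chloro or trifluoromethyl would give the same reading in the place that fluoro holds in the 2-fluorophenyl group of compound 2.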